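Moving the Methoxy Group on a Carbamate: Expected Inhibition

The source may report more compounds than this note shows. Statements on the series, on what has been measured and on what is new or still open speak of the compounds shown alone.

Measured compounds:
compound 1, `CC(C)=CCC1Cc2c(O)cc(=O)n(CCCO)c2CC1(C)C`, giving 0% in a functional assay on PANC-1 cells (Homo sapiens) for inhibition, read by MTT assay, with a stated time of 24 h, tested at 10 uM; a lower number here means less inhibition, a higher number more inhibition at the concentration tested (going by the name of the read-out)
compound 2, `CC(C)=CCC1Cc2c(OCc3ccccc3)cc(=O)n(CCCO)c2CC1(C)C`, giving 11.1%
compound 3, `COc1ccc(NC(=O)Oc2cc(=O)n(CCCO)c3c2CC(CC=C(C)C)C(C)(C)C3)cc1`, giving 0%

Compound 1 stands level with compound 3 at the digits printed, and together they are the lowest of the three numbers; only compound 2 lies beyond the scatter above them, the step being a number 11.1 percentage points higher from compound 1 to compound 2 (beyond the scatter). Compound 4, `COc1ccccc1NC(=O)Oc1cc(=O)n(CCCO)c2c1CC(CC=C(C)C)C(C)(C)C2`, differs from compound 1 in one place: (2-methoxyphenyl)carbamoyl in place of hydrogen on an oxygen on an aromatic ring. For the measured compounds named here, the measured step that bears most on this is the one to compound 3, where a closely related carbamoyl group entered at the same oxygen and the read-out showed no change at the digits printed from compound 1 to compound 3 (within the scatter). Exchanging the benzyl of compound 2 for that carbamoyl gave a number 11.1 percentage points lower from compound 2 to compound 3 (beyond the scatter). A step of about a number 2 percentage points higher from compound 1 to compound 4 (within the scatter) is therefore expected, none beyond the scatter. Compound 4 is estimated at 2%, with a range from 0% to 12%.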

Compound 4, a percentage reported as inhibition, at one concentration (the size of the read-out at that concentration, not a potency): 0%
Compound 4: the middle estimate sits 2 percentage points above what was measured; low and high end bracket the measured number.
By their numbers in this assay, from the lowest: compounds 1, 3 and 4 (each within the scatter of the next); then compound 2.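

In this assay, 2-methoxyphenyl in place of 4-methoxyphenyl on an amide-type nitrogen gave no change at the digits printed from compound 3 to compound 4 (within the scatter), so moving the methoxy group leaves the read-out unchanged for this pair. (2-Methoxyphenyl)carbamoyl in place of hydrogen gave no change at the digits printed from compound 1 to compound 4 (within the scatter), while in place of benzyl it gave a number 11.1 percentage points lower from compound 2 to compound 4 (beyond the scatter), so both carbamates now match the free hydrogen and only benzyl stands apart at this oxygen. No measured evidence accounts for these results.

On these data alone, whether a phenethyl group on this oxygen, or an amine or carboxylic acid on the carbamate's ring, would raise the number stays open.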